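Working notes: compound 1 to compound 4 in the antagonist read-out

A few compounds are considered here, and "the series" means these few. Any claim that something is new, unique, unknown or untested is made for them only; others in the source may bear on it.

Measured so far:
Compound 1 `c1ccc(NCc2ccc(CNc3ccccc3)cc2)cc1`: 64%
Compound 2 `Fc1cccc(NCc2ccc(CNc3cccc(F)n3)cc2)n1`: 85%
Compound 3 `Fc1ccc(NCc2ccc(CNc3ccc(F)cn3)cc2)nc1`: 68%

All three numbers come from a functional assay on MDA-MB-231 cells for antagonist activity at C-X-C chemokine receptor type 4 (Homo sapiens), tested at 100 nM; on this read-out lower numbers stand for a weaker effect and higher numbers for a stronger effect at the one concentration tested. Compound 1 gives the lowest of the three values. Compound 3 sits nearest to compound 1, and the gap between the two is within the usual scatter, so no order between them can be read. Compound 2 lies furthest from compound 1, and that gap is beyond the scatter, so compound 2 shows the stronger effect of the pair.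

Compound 4 `c1ccc(NCc2ccc(CNc3ncccn3)cc2)cc1` is not yet measured. It differs from compound 1 in one place:

pyrimidin-2-yl in place of phenyl on an amine nitrogen

Among the compounds with values here, no pair of measured compounds isolates this change. Compounds 2 and 3 carry ring nitrogens on both sides of the shared core and differ from compound 1 in more than one place, so their values give only a loose hint that nitrogen-containing rings on the amine nitrogen are tolerated. On that basis the step of a number 6 percentage points higher from compound 1 to compound 4 (within the scatter) is expected to be small, upward if anything, and possibly not beyond the scatter. For compound 4 the estimate in this assay is 70%, with a range from 55% to 85%.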

Compound 4, a percentage reported as inhibition, at one concentration (the size of the read-out at that concentration, not a potency): 100%
Compound 4: middle estimate off by 30 percentage points, on the low side; measured number above the stated range.
By their numbers in this assay, from the lowest: compounds 1 and 3 (each within the scatter of the next); then compound 2; then compound 4.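

In this assay, within the data shown here, the exchange of phenyl for pyrimidin-2-yl on an amine nitrogen is the first change that can be read on its own, and the step is large: a number 36 percentage points higher from compound 1 to compound 4 (beyond the scatter). This place on the core therefore does more than tolerate a nitrogen-containing ring, since a single exchange, with the anilino group at the other end of the core kept as in compound 1, is enough to shift the read-out strongly. The two rings have the same count of heavy atoms, and the counted difference is two ring nitrogens and two hydrogen-bond acceptors, but nothing measured here says which feature of the pyrimidin-2-yl group goes with the step.

The compounds shown leave open whether the step depends on both ring nitrogens, which a plain pyridin-2-yl group, a pyrazin-2-yl group or a pyrimidin-4-yl group at this place would test. Also open, from the compounds shown here alone, is what a second pyrimidin-2-yl group on the other amine nitrogen would do, and whether the stronger effect of compound 4 holds at other concentrations, as this read-out comes from one concentration only.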